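This account rests on a few compounds, and the source may have more. Where it says the series, first, only, none or still open, it means among the compounds named here.

Compound 2 `CCCCOc1ccc(NC(=O)n2nc(N)c3ccccc32)cc1` carries a butoxy group on the aniline ring that hangs from its urea, and it is the starting point of this account. In a functional assay on LOX IMVI cells (Homo sapiens) for inhibition, read by sulforhodamine B assay, with a stated time of 48 h (a lower number here means a stronger inhibitor of growth, a higher number a weaker inhibitor of growth), compound 2 gives 12200 nM, the lower of the two values in this set that are real numbers. Compound 3 `Nc1nn(C(=O)Nc2c(F)cccc2F)c2ccccc12`, which carries two fluorine atoms on the aniline ring instead, gives in this assay a value of 49300 nM, which lies beyond the scatter from compound 2. Compound 1 `COc1ccc(NC(=O)Nc2n[nH]c3ccccc23)cc1` is an isomer in which the urea sits on a ring carbon rather than a ring nitrogen and a methoxy group stands in place of the butoxy; in this assay compound 1 gives > 100000 nM, which is not a number but (the limit of > 100000 nM in this assay, at which 1 of the 3 values shown sits).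

Compound 4 `Nc1nn(C(=O)Nc2ccc(Cc3ccccc3)cc2)c2ccccc12` has not yet been measured. It differs from compound 2 in one respect: benzyl in place of butoxy on an aromatic carbon. Among the compounds with values here, no measured pair in this set isolates such a change, so there is no precedent to lean on. The estimate is that the step from compound 2 to compound 4 will be small, of the order of the scatter, and in no clear direction. The expected step from compound 2 to compound 4 is a 1.0-fold lower number from compound 2 to compound 4 (0.01 log units; within the scatter). Compound 4 is expected to give about 12000 nM in this assay, within a range of 3500 nM to 45000 nM.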

Compound 4, concentration for 50% growth inhibition: 477 nM
Beside the measured number, compound 4's estimate is 25-fold (1.40 log units) above it; measured number outside the range, below it.
By their numbers in this assay, from the lowest: compound 4; then compound 2; then compound 3. At a limit, above all of these: compound 1.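

Within the data shown here, compound 4 gives the first comparison here that isolates a single position: on an aromatic carbon of the aniline ring, para to a large group, benzyl in place of butoxy gives a 26-fold lower number from compound 2 to compound 4 (1.41 log units; beyond the scatter) in this assay. This shows that the group at this position is not a matter of indifference, since one exchange there moves the growth inhibition well beyond the scatter. The exchange replaces a chain with no ring, containing 5 heavy atoms and 1 hydrogen-bond acceptor, with a group of 7 heavy atoms that has one six-membered aromatic ring and no hydrogen-bond acceptor, and nothing measured in this set accounts for the size of the step.

The compounds shown leave open which of those differences matters, as a phenoxy group, a cyclohexylmethyl group or a longer alkyl chain at this position could show whether the aromatic ring, the oxygen or the size of the group goes with the lower number. They also leave open whether a second substituent on the aniline ring, such as a chlorine atom, would keep or lose the value of compound 4, 477 nM.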